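Terminal group exchange at the amide carbonyl of compound 3

A few compounds are considered here, and "the series" means these few. Any claim that something is new, unique, unknown or untested is made for them only; others in the source may bear on it.

Compound 3 `C=C(Br)C(=O)Nc1ccc2c(c1)/C(=C/c1ccc[nH]1)C(=O)N2` stands lowest of the three numbers in a functional assay on CCRF-CEM cells (Homo sapiens) for antiproliferative activity, read by MTT assay, with a stated time of 72 h (a lower number here means a stronger inhibitor, a higher number a weaker inhibitor), where compound 3 gives 3 nM. Compound 1 `C=C(Br)C(=O)Nc1ccc2c(c1)/C(=C/c1cccs1)C(=O)N2` gives 35 nM and compound 2 `C=C(Br)C(=O)Nc1ccc2c(c1)/C(=C\c1cccs1)C(=O)N2` gives 710 nM. The step of a 12-fold lower number from compound 1 to compound 3 (1.07 log units; beyond the scatter) is large, as is a 20-fold higher number from compound 1 to compound 2 (1.31 log units; beyond the scatter), which rests on (the fact that compounds 1 and 2 differ only in the configuration as drawn). Compound 4 `C#CC(=O)Nc1ccc2c(c1)/C(=C/c1ccc[nH]1)C(=O)N2` differs from compound 3 by ethynyl in place of 1-bromoethenyl on a carbonyl carbon. Both measured steps concern the ring on the double-bonded chain carbon or the drawn configuration of that double bond; neither touches the group on the carbonyl carbon, so none bears directly on this change, and only a step near the scatter is expected. For compound 4 in this assay the estimate is 6 nM, ranging from 1.5 nM to 25 nM, an expected step of a 2.0-fold higher number from compound 3 to compound 4 (0.30 log units; within the scatter).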

Compound 4, half-maximal inhibitory concentration: 50 nM
Estimate against measurement, compound 4: 8.3-fold (0.92 log units) below; the measured number lies above the stated range.
By their numbers in this assay, from the lowest: compound 3; then compounds 1 and 4 (each within the scatter of the next); then compound 2.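

Going by these compounds alone, the group on the carbonyl carbon, left unchanged in the earlier compounds, proves to be a sensitive position in this assay: ethynyl in place of 1-bromoethenyl costs a large step (a 17-fold higher number from compound 3 to compound 4 (1.22 log units; beyond the scatter)). The change at this carbon therefore ranks as large alongside the exchange of the ring on the double-bonded chain carbon (a 12-fold lower number from compound 1 to compound 3 (1.07 log units; beyond the scatter)). Nothing measured here accounts for the step.

As far as these compounds go, whether the bromine or the ethenyl unit carries the difference stays open; a plain ethenyl or a 1-chloroethenyl group on the same carbonyl carbon would separate the two. Also open, from the compounds shown here alone, is whether the step holds with thiophen-2-yl in place of 1H-pyrrol-2-yl.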